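Solubility notes: hydroxamate series, glycine analog

The source may hold more compounds than are shown below. What is called first, only, known or untested is meant among the compounds shown, and "the series" means these compounds.

Measured so far:
compound 1, `NC[C@H](NC(=O)c1ccc(C#Cc2ccccc2)cc1)C(=O)NO`: 13000 nM
compound 2, `CS(=O)(=O)C[C@H](NC(=O)c1ccc(C#Cc2ccccc2)cc1)C(=O)NO`: 2000 nM

In a physicochemical assay for solubility (on this read-out lower numbers stand for lower solubility and higher numbers for higher solubility), compound 2 gives 2000 nM, the lowest of the two numbers; the nearest is compound 1 with 13000 nM. Among the measured compounds shown here, the one step measured, a 6.5-fold lower number from compound 1 to compound 2 (0.81 log units; beyond the scatter), concerns an exchange of one group for another on that chain carbon.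

Compound 3, `O=C(CNC(=O)c1ccc(C#Cc2ccccc2)cc1)NO`, is not yet measured in this assay. The change from compound 2: hydrogen in place of (methylsulfonyl)methyl on a saturated chain carbon bound to an amide-type nitrogen and a carbonyl carbon. For the measured compounds named here, no measured step removes the group entirely; the step from compound 1 to compound 2 only swaps what sits there, so it bears indirectly at most. With the side group gone, the expectation for this assay is a small step, if any, downward from compound 2, near the scatter, expressed as a 1.3-fold lower number from compound 2 to compound 3 (0.12 log units; within the scatter). Compound 3 is estimated at 1500 nM, with a range from 400 nM to 6000 nM.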

Compound 3, solubility: 21000 nM
For compound 3 the middle estimate is 14-fold (1.15 log units) below the measured one, and the stated range ends below it.
By their numbers in this assay, from the lowest: compound 2; then compounds 1 and 3 (each within the scatter of the next).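

In this assay, hydrogen in place of (methylsulfonyl)methyl gives an 11-fold higher number from compound 2 to compound 3 (1.02 log units; beyond the scatter), a large step at this chain carbon and larger than the exchange of one side group for another in a 6.5-fold lower number from compound 1 to compound 2 (0.81 log units; beyond the scatter). Hydrogen in place of aminomethyl gives a 1.6-fold higher number from compound 1 to compound 3 (0.21 log units; within the scatter), so compound 1 and compound 3 are not told apart at this carbon. Compound 2 is therefore the one that stands apart, with steps beyond the scatter to both others. No supporting measurement accounts for this result.

Open, going by these compounds, is how a plain methyl, a carboxylic acid or a longer chain on this carbon would read in this assay. Among the compounds shown here, also open is whether the read-out of compound 2 follows the methylsulfonyl part itself, since no compound here separates it from the carbon that carries it.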